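Methoxy for Methyl: an Expected Cytotoxicity Step

This account rests on a few compounds, and the source may have more. Where it says the series, first, only, none or still open, it means among the compounds named here.

Measured so far:
compound 1 `Cc1ccc2c(NCc3ccco3)nc(NC(C)C)nc2c1`: > 33000 nM
compound 2 `Cc1ccc2nc(NC(C)C)nc(NCc3ccco3)c2c1`: > 33000 nM
compound 3 `COc1ccc2c(NCc3ccco3)nc(NC(C)C)nc2c1`: 16000 nM

Of the compounds shown here, three have been tested in an ADME assay on J774.A1 cells (Mus musculus) for cytotoxicity, read by MTT assay, with a stated time of 72 h; a higher number here means that more compound is needed for the effect, a lower number that less compound is needed. Compound 1 `Cc1ccc2c(NCc3ccco3)nc(NC(C)C)nc2c1` gives > 33000 nM, which is a limit of the assay rather than a number. Compound 2 `Cc1ccc2nc(NC(C)C)nc(NCc3ccco3)c2c1` gives > 33000 nM, again a limit of the assay. Compound 3 `COc1ccc2c(NCc3ccco3)nc(NC(C)C)nc2c1` gives 16000 nM, a real number.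

Compound 1 and compound 2 are built from the same atoms joined differently; the difference between their two cores is not broken down here. Compound 3 differs from compound 1 in a single place: methoxy in place of methyl on an aromatic carbon. This change made an at least 2.0-fold lower number from compound 1 to compound 3 (0.31 log units; beyond the scatter). Only the lower bound of that step is known, because the starting point sits at the limit of > 33000 nM in this assay, at which 2 of the 3 values shown sit.

Compound 4 `COc1ccc2nc(NC(C)C)nc(NCc3ccco3)c2c1` has not yet been measured in this assay. It stands to compound 2 exactly as compound 3 stands to compound 1, carrying the same change at the same place: methoxy in place of methyl on an aromatic carbon. Among the compounds with values here, since the one earlier example of this change gave an at least 2.0-fold lower number from compound 1 to compound 3 (0.31 log units; beyond the scatter), a step of about an at least 1.6-fold lower number from compound 2 to compound 4 (0.21 log units; that floor lies within the scatter) is expected here, although the starting value is itself only a limit, so the outcome may again be reported as a limit. Compound 4 is therefore expected to give roughly 20000 nM, with a likely range from 8000 nM to 50000 nM.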

Compound 4, half-maximal effective concentration: 14000 nM
Estimate against measurement, compound 4: 1.4-fold (0.15 log units) above, and the stated range covers the measured number.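

The second example points the same way as the first. In this assay, putting methoxy in place of methyl on an aromatic carbon gave an at least 2.3-fold lower number from compound 2 to compound 4 (0.37 log units; beyond the scatter), so the direction seen on the core of compound 1 appears again on a second core, and a change that lowered the number once has now lowered it twice. Set side by side, the two examples compare as follows: the same change on two cores in this assay, an at least 2.0-fold lower number (0.31 log units; beyond the scatter) from compound 1 to compound 3 and an at least 2.3-fold lower number (0.37 log units; beyond the scatter) from compound 2 to compound 4; the limit leaves it open whether they differ Each step starts from a limit of the assay rather than a real number, so the true size of either step stays unknown, and two cores sharing a direction do not show that this change has the same size wherever it is carried, nor that it would behave alike on any further core: the limit of > 33000 nM in this assay, at which 2 of the 4 values shown sit.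

The compounds shown leave open whether a different group at this same place, such as ethoxy, a chlorine atom or an amine, would lower the number as methoxy does, or whether the effect belongs to methoxy alone. They also leave open what the same swap would do elsewhere on the six-membered aromatic ring, since only this one place appears in both pairs.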